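A few compounds are considered here, and "the series" means these few. Any claim that something is new, unique, unknown or untested is made for them only; others in the source may bear on it.

In a functional assay on OVCAR-3 cells (Homo sapiens) (on this read-out higher numbers stand for weaker inhibition of growth and lower numbers for stronger inhibition of growth), compound 1 `COc1ccc(-c2cc(O)c3cccnc3n2)cc1` gives 30200 nM and compound 2 `Oc1cc(-c2ccc(Cl)cc2)nc2ncccc12` gives 23400 nM. These two numbers, the only ones available, lie within the scatter of each other, so compound 2 stands level with compound 1. Compound 3 `Cc1ccnc2nc(-c3ccc(Cl)cc3)cc(O)c12` departs from compound 2 by a single change: methyl in place of hydrogen on an aromatic carbon. The new methyl sits opposite the ring nitrogen. Within the data shown here, the only measured step, a 1.3-fold lower number from compound 1 to compound 2 (0.11 log units; within the scatter), is chloro in place of methoxy at a different place, and no measured pair tests methyl in place of hydrogen. That step gives no sign of a large change in this assay, though it cannot size this one, so no shift beyond the scatter is expected. The estimated step is a 1.2-fold lower number from compound 2 to compound 3 (0.07 log units; within the scatter). For compound 3 the expected value is 20000 nM, with an estimated range from 8000 nM to 50000 nM.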

Compound 3, concentration for 50% growth inhibition: 3160 nM
Compound 3: middle estimate off by 6.3-fold (0.80 log units), on the high side, outside the stated range (below it).
By their numbers in this assay, from the lowest: compound 3; then compounds 2 and 1 (each within the scatter of the next).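

In this assay, methyl in place of hydrogen on an aromatic carbon, opposite the ring nitrogen, gives a 7.4-fold lower number from compound 2 to compound 3 (0.87 log units; beyond the scatter) and so moves the number beyond the scatter. The only earlier step, chloro in place of methoxy at a different place, gave a 1.3-fold lower number from compound 1 to compound 2 (0.11 log units; within the scatter) and stayed within the scatter, so this position is the first shown to respond to a change, and a single added carbon is enough. Nothing on hand accounts for the size of this step.

The compounds shown leave open whether the effect is particular to methyl or would also appear with a longer chain such as ethyl, or with an amine, at the same position. They also leave open whether it would hold with methoxy in place of chloro, since methyl at this position appears only alongside chloro.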